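This account rests on a few compounds, and the source may have more. Where it says the series, first, only, none or still open, it means among the compounds named here.

In a functional assay on MDA-MB-231 cells (Homo sapiens), read by microscopy and transwell migration, with a stated time of 24 h (a higher number here means a weaker inhibitor, a lower number a stronger inhibitor), compound 2 `Cc1ccc(-c2cnc(NC(=O)c3ccccc3)s2)cc1` gives 308 nM. Compound 1 `CCCCn1c(-c2ccc(C)cc2C)cs/c1=N\C(=O)c1ccccc1` gives 196 nM, and these two values lie within the usual scatter of each other, so neither can be ranked above the other. For compound 3 `Cc1ccc(-c2cn(C)/c(=N/C(=O)c3ccccc3)s2)cc1` the assay reports only a limit, > 25000 nM, and not a number. Compound 2 therefore stands level with compound 1 among the values that are true numbers.

Compound 4 `Cc1ccc(-c2cnc(N(C)C(=O)c3ccccc3)s2)cc1` has the structure of compound 2 with a single edit: methyl in place of hydrogen on an amide-type nitrogen. The amide hydrogen is gone, and nothing else changes.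

Among the compounds with values here, no pair of measured compounds differs in just one place, so no measured step shows what an edit like this does here. The expectation is therefore a rough one: a clear rise in the number, meaning a weaker inhibitor, of a size beyond the scatter. The data also contain (the limit of > 25000 nM in this assay, at which 1 of the 3 values shown sits), so a much larger rise remains possible, and compound 4 may likewise give only a limit. The expected change is an 8.1-fold higher number from compound 2 to compound 4 (0.91 log units; beyond the scatter). Compound 4 is estimated to give about 2500 nM, with an expected range of 300 nM to 20000 nM.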

Compound 4, half-maximal inhibitory concentration: 1090 nM
Compound 4: the middle estimate sits 2.3-fold (0.36 log units) above what was measured; low and high end bracket the measured number.
By their numbers in this assay, from the lowest: compounds 1 and 2 (each within the scatter of the next); then compound 4. At a limit, above all of these: compound 3.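

In this assay, within the data shown here, putting methyl in place of the amide hydrogen gives a 3.5-fold higher number from compound 2 to compound 4 (0.55 log units; beyond the scatter) and is the first single edit measured in this set. It shows that this amide-type nitrogen tolerates losing its hydrogen to a methyl at a modest price: compound 4 gives 1090 nM and not a limit, so the edit weakens the compound without abolishing inhibition in this assay. The only limit in the set belongs to a compound that differs from compound 2 in more than one place, so it does not measure this edit directly: the limit of > 25000 nM in this assay, at which 1 of the 4 values shown sits.

From the compounds shown here alone, one methyl is a single point, so it remains open whether the number would rise further with a longer chain such as propyl on this nitrogen, or shift differently with a chain carrying an amine or a carboxylic acid. The compounds shown also do not separate the loss of the amide hydrogen from the arrival of the methyl as the source of the rise.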